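Extending the hydroxycarbamoyl chain beyond compound 3

The source may hold more compounds than are shown below. What is called first, only, known or untested is meant among the compounds shown, and "the series" means these compounds.

Within the data shown here, in a functional assay on HEL cells (Homo sapiens) for inhibition, read by MTT assay, with a stated time of 48 h (a lower number here means a stronger inhibitor, a higher number a weaker inhibitor), compound 3 (`O=C(CCCCCCOc1no[n+]([O-])c1S(=O)(=O)c1ccccc1)NO`) gives 9330 nM as the highest number so far, with compound 1 (`O=S(=O)(c1ccccc1)c1c(OCCCCCCO)no[n+]1[O-]`) at 2160 nM and compound 2 (`O=C(CCCCOc1no[n+]([O-])c1S(=O)(=O)c1ccccc1)NO`) at 1030 nM on the lower side. Compound 4 (`O=C(CCCCCCCOc1no[n+]([O-])c1S(=O)(=O)c1ccccc1)NO`) has not yet been measured. It carries (hydroxycarbamoyl)methyl in place of hydroxycarbamoyl on a saturated chain carbon, six bonds along the chain from an oxygen on an aromatic ring, and the counted change is (hydroxycarbamoyl)methyl in place of hydroxycarbamoyl on a saturated chain carbon, six bonds along the chain from an oxygen on an aromatic ring with nothing else altered.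

Among the measured compounds shown here, the closest precedent is the one lengthening step between hydroxycarbamoyl compounds, a 9.1-fold higher number from compound 2 to compound 3 (0.96 log units; beyond the scatter) in the upward direction. The steps of a 2.1-fold lower number from compound 1 to compound 2 (0.32 log units; beyond the scatter) and a 4.3-fold higher number from compound 1 to compound 3 (0.64 log units; beyond the scatter) also replace the chain end, and they run in opposite directions, so they say little here. The present extension is smaller than 2-(hydroxycarbamoyl)ethyl in place of hydroxycarbamoyl, and one pair cannot fix a trend. No step beyond the scatter is therefore expected, and the expected step is a 1.1-fold higher number from compound 3 to compound 4 (0.03 log units; within the scatter) as a slight upward drift at most. For compound 4 the estimated value is 10000 nM with an expected range from 3000 nM to 30000 nM in this read-out.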

Compound 4, half-maximal inhibitory concentration: 10800 nM
Compound 4: middle estimate off by 1.1-fold (0.03 log units), on the low side, within the range that was stated.
By their numbers in this assay, from the lowest: compound 2; then compound 1; then compounds 3 and 4 (each within the scatter of the next).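

In this assay, among these compounds, the step of a 1.2-fold higher number from compound 3 to compound 4 (0.06 log units; within the scatter) shows that (hydroxycarbamoyl)methyl in place of hydroxycarbamoyl at this position, six bonds along the chain from an oxygen on an aromatic ring, gives no change beyond the scatter, so the large upward step a 9.1-fold higher number from compound 2 to compound 3 (0.96 log units; beyond the scatter) has no counterpart here. The step of a 10-fold higher number from compound 2 to compound 4 (1.02 log units; beyond the scatter) lies beyond the scatter, placing compound 3 and compound 4 together on the high side of compound 2. The step of a 5.0-fold higher number from compound 1 to compound 4 (0.70 log units; beyond the scatter) shows that a hydroxycarbamoyl chain end does not by itself give a lower number than a hydroxy end, with compound 2 going against any such rule in the opposite direction.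

No supporting data bear on why the number depends on chain length. Compound 2 gives 1030 nM. Open, on these data alone, is whether a carboxylic acid or a primary amide at the chain end, or a chain shorter than that of compound 2, would match or go below that number.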